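The source may hold more compounds than are shown below. What is called first, only, known or untested is meant among the compounds shown, and "the series" means these compounds.

Compound 1, `O=C1/C(=C/c2ccccc2Cl)Cc2ccccc21`: in a functional assay on CCRF-CEM cells (Homo sapiens) for inhibition (on this read-out lower numbers stand for stronger inhibition and higher numbers for weaker inhibition), compound 1 gives 57000 nM.
Compound 2, `O=C1/C(=C/c2ccc(Cl)cc2Cl)Cc2ccccc21`: in this assay compound 2 reaches only a limit, > 500000 nM.

Within the data shown here, compound 1 is thus the only compound with a number in this assay; the other value shown is the limit of > 500000 nM in this assay, at which 1 of the 2 values shown sits, a limit and not a number. The piece follows the step from compound 1 to compound 3, `Cc1ccccc1/C=C1\Cc2ccccc2C1=O`, where (methyl in place of chloro on an aromatic carbon).

Among the measured compounds shown here, only one measured step bears on this change, and it does so loosely: an at least 8.7-fold higher number from compound 1 to compound 2 (0.94 log units; beyond the scatter), which adds a second chloro to the ring rather than exchanging the one already present. The change in compound 3 exchanges the chloro for a methyl, the size of the group changing little and the ring otherwise unchanged. For the measured compounds named here, no measured step shows what such an exchange does in this assay, so no direction beyond the scatter is expected, and the estimate leans on compound 1 alone.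

Compound 3 is therefore expected to sit near compound 1, with the step of a 1.1-fold higher number from compound 1 to compound 3 (0.02 log units; within the scatter) lying within the scatter; compound 3 is estimated at 60000 nM, between 25000 nM and 150000 nM.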

Compound 3, half-maximal inhibitory concentration: 56500 nM
For compound 3 the middle estimate is 1.1-fold (0.03 log units) above the measured one, within the range that was stated.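

In this assay, the exchange of methyl for chloro on this aromatic carbon, ortho to a large group, gives a 1.0-fold lower number from compound 1 to compound 3 (0.00 log units; within the scatter) and so stays within the scatter. Among these compounds, this is the first measured exchange at the position itself, as the earlier step, an at least 8.7-fold higher number from compound 1 to compound 2 (0.94 log units; beyond the scatter), concerned a second chloro added to the ring and left the first in place; here the chlorine atom proves unnecessary for the level of compound 1, and one carbon in its place serves equally well in this read-out. Among the compounds shown here, the data show only that the two groups, each of one heavy atom and with no hydrogen-bond donors or acceptors, cannot be told apart here, and nothing on hand offers an explanation for this.

On these data alone, it remains open whether an amine, a carboxylic acid or a longer chain on this aromatic carbon would stay level with compound 1 and compound 3. Also open, as far as these compounds go, is whether a second methyl, in the place that the second chloro takes in compound 2, would carry the same penalty as that chloro.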